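Nitro for cyano on the chromene core, second time

This account rests on a few compounds, and the source may have more. Where it says the series, first, only, none or still open, it means among the compounds named here.

In a functional assay (aorta) with Rattus norvegicus as the target (on this read-out lower numbers stand for an effect already at smaller amounts and higher numbers for an effect only at larger amounts of compound), compound 1 `N#Cc1ccc2c(c1)[C@@H](N1CCCC1=O)[C@H](O)C(CF)(CF)O2` gives 85.1 nM and compound 2 `O=C1CCCN1[C@@H]1c2cc([N+](=O)[O-])ccc2OC(CF)(CF)[C@H]1O` gives 24 nM. The two differ in one place, (nitro in place of cyano on an aromatic carbon), and this change gave a 3.5-fold lower number from compound 1 to compound 2 (0.55 log units; beyond the scatter). Compound 3 `N#Cc1ccc2c(c1)C(N1CCCCC1=O)=CC(CF)(CF)O2` is built on a different core; how the core of compound 3 differs from the core of compound 1 is not broken down here. In this assay compound 3 gives 162 nM, a number that lies within the usual scatter of the value of compound 1 and is well apart from the value of compound 2. Compound 4 `O=C1CCCCN1C1=CC(CF)(CF)Oc2ccc([N+](=O)[O-])cc21` has not been measured. It arises from compound 3 by the same change already seen between compound 1 and compound 2, (nitro in place of cyano on an aromatic carbon), at a place described in the same words. Because the first occurrence gave a 3.5-fold lower number from compound 1 to compound 2 (0.55 log units; beyond the scatter), a step of about the same size is expected here, a 3.5-fold lower number from compound 3 to compound 4 (0.55 log units; beyond the scatter), with a single earlier example as the only support. Compound 4 is therefore estimated at 46 nM, most likely between 20 nM and 110 nM.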

Compound 4, half-maximal effective concentration: 17.4 nM
Compound 4: the middle estimate sits 2.6-fold (0.42 log units) above what was measured; measured number outside the range, below it.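

In this assay, nitro in place of cyano again goes with a lower number, a 9.3-fold lower number from compound 3 to compound 4 (0.97 log units; beyond the scatter), so the direction of the change seen on the core of compound 1 also appears on the core of compound 3. Set side by side, the two steps agree within what repeated measurements allow: the same change on two cores in this assay, a 3.5-fold lower number (0.55 log units; beyond the scatter) from compound 1 to compound 2 and a 9.3-fold lower number (0.97 log units; beyond the scatter) from compound 3 to compound 4, 2.6-fold (0.42 log units) apart, within the scatter of two such steps. This supports carrying the change from one of these cores to the other, but two examples do not show that it will work on every core in the series, the gap between the steps cannot be read as an effect of the core, and the numbers do not say why nitro gives the lower value.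

The compounds shown compare only cyano and nitro on this aromatic carbon, so it remains open how another group there, such as an amine or a carboxylic acid, would behave. From the compounds shown here alone, it also remains open whether the step would keep its direction on a third core.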